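Trading pyridin-4-yl for trifluoromethyl in a small series

A few compounds are considered here, and "the series" means these few. Any claim that something is new, unique, unknown or untested is made for them only; others in the source may bear on it.

In a functional assay on KG-1 cells (Homo sapiens) for cytotoxicity, read by luminescence and CellTiter-Glo, with a stated time of 3 days (a higher number here means a weaker inhibitor, a lower number a stronger inhibitor), compound 1 `N#Cc1ccc(NC(=O)c2cc(-c3ccncc3)ccc2O)cc1` gives 7990 nM and compound 2 `N#Cc1ccc(NC(=O)c2ccc(-c3cccnc3)cc2O)cc1` gives 7940 nM, two values that lie within the scatter of each other. Compound 3 `O=C(Nc1ccc(OC(F)(F)F)cc1Cl)c1cc(Cl)ccc1O` gives 620 nM in this assay, a number lower than that of compound 1 by a margin beyond the scatter. Compound 1 therefore stands at the high end of the numbers, level with compound 2.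

Compound 4 `N#Cc1ccc(NC(=O)c2cc(C(F)(F)F)ccc2O)cc1` has not yet been measured. It keeps the core of compound 1 and differs in one place: trifluoromethyl in place of pyridin-4-yl on an aromatic carbon on an aromatic carbon. That carbon belongs to a six-membered aromatic ring of carbon only and sits para to a hydroxy group.

Within the data shown here, no two measured compounds differ in just one place, so nothing shows directly what this exchange does. Among the measured compounds shown here, the only lower number available is that of compound 3 at 620 nM in this assay, a thin basis for expecting a moderate move towards a lower number, though a result within the scatter of compound 1 remains possible. The expected size of the change is a 3.2-fold lower number from compound 1 to compound 4 (0.50 log units; beyond the scatter) in this assay as estimated here. Compound 4 is expected at 2500 nM with an estimated range from 700 nM to 8000 nM in this assay.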

Compound 4, half-maximal inhibitory concentration: 4810 nM
Compound 4: the middle estimate sits 1.9-fold (0.28 log units) below what was measured, and the stated range covers the measured number.
By their numbers in this assay, from the lowest: compound 3; then compounds 4, 2 and 1 (each within the scatter of the next).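

In this assay, among these compounds, the exchange of pyridin-4-yl for trifluoromethyl on the aromatic carbon para to a hydroxy group gives a 1.7-fold lower number from compound 1 to compound 4 (0.22 log units; within the scatter), a step that stays within the scatter and is the first direct reading of a single change. At this position, then, a six-membered aromatic ring with a hydrogen-bond acceptor and a smaller group with no ring and no acceptor cannot be told apart by this read-out, so neither the ring nor its acceptor is shown to matter for the number in this pair. No measurement bearing on the result offers a reason for this level reading.

The compounds shown leave open whether an amine, a carboxylic acid or a longer alkyl chain on this same carbon would move the number beyond the scatter, or whether plain hydrogen there would read level with both groups. They also leave open whether pyridin-4-yl and trifluoromethyl would stay level on a core carrying something other than the nitrile.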